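Swapping methoxy for chloro on a chalcone growth inhibitor

The compounds below may be only part of what the source reports. "The series", "measured", "known", "first", "only" and "open" are said of these compounds alone.

Of the compounds shown here, two have been tested so far in a functional assay on T47D cells (Homo sapiens) for inhibition; a higher number here means a weaker inhibitor of growth, a lower number a stronger inhibitor of growth. Compound 1, `O=C(/C=C/c1cccc(O)c1)c1cccc(-n2cc(-c3ccc(Cl)cc3)[nH]c2=O)c1`, gives 1920 nM. Compound 2, `COc1ccc(-c2cn(-c3cccc(C(=O)/C=C/c4ccc(O)c(OC)c4)c3)c(=O)[nH]2)cc1`, gives 3600 nM. Compound 2 has the higher of the two numbers, but its gap to compound 1 is within the scatter, so the two cannot be ranked against each other on these data.

Compound 3, `COc1cc(/C=C/C(=O)c2cccc(-n3cc(-c4ccc(Cl)cc4)[nH]c3=O)c2)ccc1O`, has not yet been measured. It is built from compound 2 by a single change: chloro in place of methoxy on an aromatic carbon. For the measured compounds named here, compound 1 already carries a chloro on its corresponding ring, though the other end of its molecule differs from that of compound 2 and compound 3, so no single step isolates this swap.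

Going by the values given here, with no measured step for this change, and with the two known values sitting within the scatter of each other, the step from compound 2 to compound 3 in this assay is expected to be small, in either direction or none beyond the scatter, as a 1.4-fold lower number from compound 2 to compound 3 (0.14 log units; within the scatter). Compound 3 is estimated at 2600 nM in this assay, in a range from 1000 nM to 6500 nM.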

Compound 3, concentration for 50% growth inhibition: 3090 nM
The estimate for compound 3 lay 1.2-fold (0.07 log units) below the measured number; the range from low to high includes it.
By their numbers in this assay, from the lowest: compounds 1, 3 and 2 (each within the scatter of the next).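

In this assay, the first direct read on this position comes from the swap of 4-methoxyphenyl to 4-chlorophenyl, with chloro in place of methoxy on an aromatic carbon para to a large group (a 1.2-fold lower number from compound 2 to compound 3 (0.07 log units; within the scatter)), so compounds with these two groups cannot be told apart. Compound 3 also gives a single-place comparison at the other end of the molecule, where 4-hydroxy-3-methoxyphenyl stands in place of 3-hydroxyphenyl (a 1.6-fold higher number from compound 1 to compound 3 (0.21 log units; within the scatter)), and these two compounds cannot be told apart either, whereas compound 1 and compound 2 differ in two places and offered no such reading. Nothing measured here offers an explanation for how closely these compounds match.

Methoxy and chloro are the only groups shown at this position, so it remains open whether an amine, a carboxylic acid or a longer chain such as butoxy would move the number beyond the scatter. As far as these compounds go, at the other end, it also remains open whether an amine in place of the hydroxy group would do so.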